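A methoxy moved: from compound 3 to compound 4

This account rests on a few compounds, and the source may have more. Where it says the series, first, only, none or still open, it means among the compounds named here.

In an assay on thoracic aorta for inhibition of Voltage-gated L-type calcium channel (Rattus norvegicus) (on this read-out lower numbers stand for stronger inhibition and higher numbers for weaker inhibition), compound 3 `COc1cccc(/C=C/COC(=O)C2=C(C(OC)OC)NC(C)=C(C(=O)O)C2c2cccc(Cl)c2)c1` gives 4400 nM, the second highest of the three numbers. Compound 1 `COC(OC)C1=C(C(=O)OC/C=C/c2ccccc2)C(c2cccc(Cl)c2)C(C(=O)O)=C(C)N1` gives 8100 nM and compound 2 `COC(OC)C1=C(C(=O)OC/C=C/c2ccc(F)cc2)C(c2cccc(Cl)c2)C(C(=O)O)=C(C)N1` gives 2000 nM. The step of a 1.8-fold lower number from compound 1 to compound 3 (0.27 log units; within the scatter) stays within the scatter, whereas a 2.2-fold higher number from compound 2 to compound 3 (0.34 log units; beyond the scatter) and a 4.1-fold lower number from compound 1 to compound 2 (0.61 log units; beyond the scatter) lie beyond it. Compound 4 `COc1ccc(/C=C/COC(=O)C2=C(C(OC)OC)NC(C)=C(C(=O)O)C2c2cccc(Cl)c2)cc1` differs from compound 3 by 4-methoxyphenyl in place of 3-methoxyphenyl on a double-bonded chain carbon bound to a double-bonded chain carbon. No measured pair shows this exact shift; the nearest bearing comes from compound 2, which carries a 4-fluorophenyl group on the same double-bonded chain carbon and has the lowest number shown, 2000 nM. On that basis one expects a step of a 1.5-fold lower number from compound 3 to compound 4 (0.17 log units; within the scatter), a modest lowering at most. Compound 4 is therefore estimated at 3000 nM, within a range from 1000 nM to 9000 nM.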

Compound 4, half-maximal inhibitory concentration: 540 nM
Beside the measured number, compound 4's estimate is 5.6-fold (0.74 log units) above it; the whole stated range lies above it.
By their numbers in this assay, from the lowest: compound 4; then compound 2; then compounds 3 and 1 (each within the scatter of the next).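

In this assay, the place of the methoxy on the phenyl ring proves decisive: an 8.1-fold lower number from compound 3 to compound 4 (0.91 log units; beyond the scatter), although the 3-methoxyphenyl and 4-methoxyphenyl groups hold the same atoms. Methoxy in this place also outdoes the fluoro of compound 2, with a 3.7-fold lower number from compound 2 to compound 4 (0.57 log units; beyond the scatter), and the hydrogen of compound 1, with a 15-fold lower number from compound 1 to compound 4 (1.18 log units; beyond the scatter), the largest step in the set. No measurement shown accounts for this difference between the two methoxy placements. As far as these compounds go, whether a 4-ethoxyphenyl or 4-hydroxyphenyl group on this chain carbon would match the 4-methoxyphenyl group remains open.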